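A few compounds are considered here, and "the series" means these few. Any claim that something is new, unique, unknown or untested is made for them only; others in the source may bear on it.

Among the measured compounds shown here, in an ADME assay on CCRF-CEM cells (Homo sapiens) for cytotoxicity, with a stated time of 4 days (a higher number here means that more compound is tolerated, a lower number that less compound is tolerated), compound 1 `Cc1cn([C@@H]2O[C@H](CO[Si](C)(C)C(C)(C)C)[C@@]3(OS(=O)(=O)C=C3N)[C@H]2O[Si](C)(C)C(C)(C)C)c(=O)n(C(=O)c2ccccc2)c1=O` gives 54000 nM, the highest of the three numbers measured so far. Compound 2 `COC(=O)CCCC(=O)n1c(=O)c(C)cn([C@@H]2O[C@H](CO[Si](C)(C)C(C)(C)C)[C@@]3(OS(=O)(=O)C=C3N)[C@H]2O[Si](C)(C)C(C)(C)C)c1=O` gives 9900 nM, and compound 3 `CNC(=O)CCCC(=O)n1c(=O)c(C)cn([C@@H]2O[C@H](CO[Si](C)(C)C(C)(C)C)[C@@]3(OS(=O)(=O)C=C3N)[C@H]2O[Si](C)(C)C(C)(C)C)c1=O` gives 9100 nM. Compound 4 `Cc1cn([C@@H]2O[C@H](CO[Si](C)(C)C(C)(C)C)[C@@]3(OS(=O)(=O)C=C3N)[C@H]2O[Si](C)(C)C(C)(C)C)c(=O)n(C(=O)CCCC(=O)N(C)C)c1=O` has not yet been measured. It differs from compound 1 by a single change, 3-(dimethylcarbamoyl)propyl in place of phenyl on a carbonyl carbon. Two measured steps replace the same phenyl with a similar chain. With 3-(methoxycarbonyl)propyl there is a 5.5-fold lower number from compound 1 to compound 2 (0.74 log units; beyond the scatter), and with 3-(methylcarbamoyl)propyl there is a 5.9-fold lower number from compound 1 to compound 3 (0.77 log units; beyond the scatter). Both steps are modest but beyond the scatter. Methylamino in place of methoxy on a carbonyl carbon gives a 1.1-fold lower number from compound 2 to compound 3 (0.04 log units; within the scatter), which is within the scatter. For the measured compounds named here, no measured compound carries the dimethylcarbamoyl end, so some uncertainty remains. A modest step of similar size towards a lower number is therefore expected in this assay. The expected step is a 5.7-fold lower number from compound 1 to compound 4 (0.75 log units; beyond the scatter). For compound 4 the estimated value is 9500 nM, with an expected range from 5000 nM to 19000 nM.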

Compound 4, half-maximal cytotoxic concentration: 9500 nM
For compound 4 middle estimate and measured number coincide at the digits printed; the range from low to high includes it.
By their numbers in this assay, from the lowest: compounds 3, 4 and 2 (each within the scatter of the next); then compound 1.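

In this assay, a third chain in place of phenyl on the carbonyl carbon again gives a modest step, a 5.7-fold lower number from compound 1 to compound 4 (0.75 log units; beyond the scatter). Methyl in place of hydrogen on the amide-type nitrogen gives a 1.0-fold higher number from compound 3 to compound 4 (0.02 log units; within the scatter), and dimethylamino in place of methoxy on the carbonyl carbon gives a 1.0-fold lower number from compound 2 to compound 4 (0.02 log units; within the scatter), so both steps stay within the scatter. Among compound 2, compound 3 and compound 4, the three chain ends therefore cannot be told apart, while all three compounds lie beyond the scatter below compound 1, which carries the phenyl.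

No available evidence explains the gap between the phenyl and the chains. Going by these compounds, it remains open whether a chain ending in a carboxylic acid or a free amine, or a longer chain, would give a similar number.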